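The compounds below may be only part of what the source reports. "The series", "measured", "known", "first", "only" and "open" are said of these compounds alone.

Compound 1 `O=C(O)c1ccccc1-c1ccc(CCc2ncc(Cc3ccccc3Cl)[nH]2)cc1`: 22 nM
Compound 2 `N#Cc1cccc(Cc2cnc(CCc3ccc(-c4ccccc4C(=O)O)cc3)[nH]2)c1`: 20 nM
Compound 3 `O=C(O)c1ccccc1-c1ccc(CCc2ncc(Cc3ccc(F)cc3)[nH]2)cc1`: 50 nM

In an in vitro functional assay on cells for agonist activity at Bombesin receptor subtype-3 (Mus musculus), read by luminescence and calcium flux (on this read-out lower numbers stand for an effect already at smaller amounts and higher numbers for an effect only at larger amounts of compound), compound 3 stands at the highest of the three numbers: the steps of a 2.3-fold higher number from compound 1 to compound 3 (0.36 log units; beyond the scatter) and a 2.5-fold higher number from compound 2 to compound 3 (0.40 log units; beyond the scatter) were modest but beyond the scatter, whereas a 1.1-fold lower number from compound 1 to compound 2 (0.04 log units; within the scatter) lay within it. Compound 4 `CC(C)CCc1cnc(CCc2ccc(-c3ccccc3C(=O)O)cc2)[nH]1` differs from compound 3 by isobutyl in place of 4-fluorophenyl on a saturated chain carbon bound to an aromatic carbon. For the measured compounds named here, no measured step bears directly on this change; every step so far exchanged one of 2-chlorophenyl, 3-cyanophenyl and 4-fluorophenyl for another at the same place, and each moved the number only modestly. On these data alone, removing the ring altogether is untested here, so the expectation is uncertain and leans toward a somewhat higher number, a 2.4-fold higher number from compound 3 to compound 4 (0.38 log units; beyond the scatter). Compound 4 is therefore estimated at 120 nM, within a range of 30 nM to 500 nM.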

Compound 4, half-maximal effective concentration: 10 nM
Compound 4: the middle estimate sits 12-fold (1.08 log units) above what was measured; the measured number lies below the stated range.
By their numbers in this assay, from the lowest: compounds 4, 2 and 1 (each within the scatter of the next, the first and the last beyond it); then compound 3.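

In this assay, a ring is not needed at this place on a saturated chain carbon bound to an aromatic carbon: isobutyl, with no ring, gives a 5.0-fold lower number from compound 3 to compound 4 (0.70 log units; beyond the scatter) and also a 2.2-fold lower number from compound 1 to compound 4 (0.34 log units; beyond the scatter) as modest steps. Compound 2 goes against this trend, with a 2.0-fold lower number from compound 2 to compound 4 (0.30 log units; within the scatter) leaving the two compounds indistinguishable. No evidence is available to explain the result. Open, on these data alone, is whether an amine, a carboxylic acid or a longer chain at this place would keep the number as low as compound 4 does.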